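Moving the methoxy group: compound 3 to compound 4

The compounds below may be only part of what the source reports. "The series", "measured", "known", "first", "only" and "open" are said of these compounds alone.

In a physicochemical assay, with a stated time of 6 min (on this read-out lower numbers stand for stronger inhibition and higher numbers for weaker inhibition), compound 1 `O=C(Nc1ccc(F)cc1)Nc1nc(-c2cc3ccccc3o2)cs1` gives 1130 nM, compound 2 `O=C(Nc1nc(-c2cc3ccccc3o2)cs1)Nc1ccccc1F` gives 2630 nM and compound 3 `COc1ccc(NC(=O)Nc2nc(-c3cc4ccccc4o3)cs2)cc1` gives 17400 nM. Compound 3 therefore has the highest number of the three and is the weakest inhibitor so far.

Compound 4 `COc1cccc(NC(=O)Nc2nc(-c3cc4ccccc4o3)cs2)c1` has 3-methoxyphenyl in place of 4-methoxyphenyl on an amide-type nitrogen.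

Within the data shown here, the nearest precedent is the exchange of 4-fluorophenyl for 2-fluorophenyl, with a 2.3-fold higher number from compound 1 to compound 2 (0.37 log units; beyond the scatter), a modest step. Two larger measured steps, a 15-fold higher number from compound 1 to compound 3 (1.19 log units; beyond the scatter) and a 6.6-fold higher number from compound 2 to compound 3 (0.82 log units; beyond the scatter), replace one group with another, which the present change does not do. Among the measured compounds shown here, no measured pair moves a methoxy group, so the direction remains uncertain. A modest step towards a lower number is tentatively expected, given the position of compound 3 at the top of the measured numbers. The estimated change is a 1.9-fold lower number from compound 3 to compound 4 (0.29 log units; within the scatter). For compound 4 the expected value is 9000 nM, with an estimated range of 2500 nM to 30000 nM.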

Compound 4, half-maximal inhibitory concentration: 200 nM
The estimate for compound 4 lay 45-fold (1.65 log units) above the measured number, outside the stated range (below it).
By their numbers in this assay, from the lowest: compound 4; then compound 1; then compound 2; then compound 3.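

In this assay, among these compounds, the methoxy group alone changes place, with the atoms unchanged, and this gives an 87-fold lower number from compound 3 to compound 4 (1.94 log units; beyond the scatter); the place of the methoxy group on the phenyl ring therefore matters far more here than the earlier compounds could show. The 3-methoxyphenyl group also gives a 13-fold lower number from compound 2 to compound 4 (1.12 log units; beyond the scatter) and a 5.7-fold lower number from compound 1 to compound 4 (0.75 log units; beyond the scatter), which makes compound 4 the strongest inhibitor of the four and shows that a methoxy group does not by itself weaken inhibition, as compound 3 alone might have suggested. No measurement is available that accounts for the size of this step.

On these data alone, it remains open whether the gain survives if the methoxy group is replaced by a longer chain such as ethoxy, or by a hydroxyl or an amine at the same place. As far as these compounds go, the fluoro pair covers only 2-fluorophenyl and 4-fluorophenyl, so whether 3-fluorophenyl would follow the methoxy result also remains open.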